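The source may report more compounds than this note shows. Statements on the series, on what has been measured and on what is new or still open speak of the compounds shown alone.

Working notes on the series in an in vitro assay on BaF3 cells for displacement of a labelled ligand from C-X-C chemokine receptor type 3 (Homo sapiens); a lower number here means a stronger inhibitor, a higher number a weaker inhibitor.

Of the compounds shown here, three of the shared core have been measured. Compound 1 `CC[C@H]1CN(c2nc(N)c(C(N)=O)nc2Cl)CCN1C1CCN(Cc2ccc(C#N)cc2)CC1` gives 8.5 nM. Compound 2 `CC[C@H]1CN(c2nc(N)c(C(=O)NCC(C)O)nc2Cl)CCN1C1CCN(Cc2ccc(Cl)cc2)CC1` gives 0.3 nM, the lowest of the three numbers. Compound 3 `CC[C@H]1CN(c2nc(N)c(C(=O)NCCNS(N)(=O)=O)nc2Cl)CCN1C1CCN(Cc2ccc(F)c(F)c2)CC1` gives 9 nM. Compound 2 thus stands well apart from the other two: the gap to compound 1 and the gap to compound 3 are each beyond the scatter, so compound 2 is the strongest inhibitor among the measured members. Compounds 1 and 3 lie within the scatter of each other and are not ordered here.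

Compound 4 `CC[C@H]1CN(c2nc(N)c(C(=O)NCCNS(C)(=O)=O)nc2Cl)CCN1C1CCN(Cc2ccc(Cl)cc2)CC1` has not yet been measured. It differs from compound 2 in one place: (methanesulfonamido)methyl in place of 1-hydroxyethyl on a saturated chain carbon bound to an amide-type nitrogen. For the measured compounds named here, no measured pair in the set isolates this change, and compound 3, which carries a related chain on the carbamoyl group, also differs from compound 2 at the benzyl ring, so its value cannot be read as this step alone.

On what is available, a moderate weakening is expected, with the step from compound 2 to compound 4 estimated at a 3.3-fold higher number from compound 2 to compound 4 (0.52 log units; beyond the scatter); a result within the scatter of compound 2 is not excluded. Compound 4 is expected to give about 1 nM, estimated between 0.3 nM and 4 nM.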

Compound 4, half-maximal inhibitory concentration: 4.4 nM
Beside the measured number, compound 4's estimate is 4.4-fold (0.64 log units) below it; measured number outside the range, above it.
By their numbers in this assay, from the lowest: compound 2; then compounds 4, 1 and 3 (each within the scatter of the next, the first and the last beyond it).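

In this assay, replacing (2-hydroxypropyl)carbamoyl with (2-(methanesulfonamido)ethyl)carbamoyl while the rest of the structure stays fixed gives a 15-fold higher number from compound 2 to compound 4 (1.17 log units; beyond the scatter), a large step. For the compounds shown here, this pair is the first in the set to isolate the chain on the amide-type nitrogen, and it shows that this position alone, with no change at the benzyl ring, can move the number well beyond the scatter. Nothing at hand bears on the origin of this step, so it stands as an observation only.

A single pair cannot separate the gain of the methanesulfonamido group from the loss of the hydroxyl group and the methyl branch of the 2-hydroxypropyl chain, since all of these change together in this step. Going by these compounds, it remains open where chains such as 2-hydroxyethyl, 2-aminoethyl or 2-acetamidoethyl would fall relative to compound 2, and whether a step of this size would hold with a nitrile or another substituent on the benzyl ring in place of the chlorine.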